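Chloro for trifluoromethyl on the aniline ring of compound 2

This account rests on a few compounds, and the source may have more. Where it says the series, first, only, none or still open, it means among the compounds named here.

Two members of this series have been measured in a functional assay on U-87MG ATCC cells for antiproliferative activity against U-87 MG (Homo sapiens), read by spectrophotometry, with a stated time of 2 days; on this read-out higher numbers stand for weaker inhibition of growth and lower numbers for stronger inhibition of growth. Compound 1 `COc1cc(N2CCN(C(C)=O)CC2)ccc1Nc1ncc(C(F)(F)F)c(N2Cc3cccc(N(C)S(C)(=O)=O)c3C2)n1` gives 4700 nM. Compound 2 `CN(c1cccc2c1CN(c1nc(Nc3cc(C(F)(F)F)cc(C(F)(F)F)c3)ncc1C(F)(F)F)C2)S(C)(=O)=O` gives 16800 nM, the higher of the two numbers, and its gap to compound 1 lies beyond the usual scatter of repeated measurements, so compound 2 is the weaker growth inhibitor of the pair.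

Compound 3 `CN(c1cccc2c1CN(c1nc(Nc3cc(Cl)cc(C(F)(F)F)c3)ncc1C(F)(F)F)C2)S(C)(=O)=O` is the next compound to be tested in this assay. It differs from compound 2 in one place: chloro in place of trifluoromethyl on an aromatic carbon.

Among the compounds with values here, no step between measured compounds has been recorded that matches this change, so there is nothing itself to calibrate it. A modest shift toward a lower number is expected, with a 1.4-fold lower number from compound 2 to compound 3 (0.15 log units; within the scatter) as the estimated step, though it may well stay within the scatter. Compound 3 is accordingly expected to give about 12000 nM, within a range of 4000 nM to 40000 nM.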

Compound 3, concentration for 50% growth inhibition: 5500 nM
Beside the measured number, compound 3's estimate is 2.2-fold (0.34 log units) above it, and the stated range covers the measured number.
By their numbers in this assay, from the lowest: compounds 1 and 3 (each within the scatter of the next); then compound 2.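

In this assay, chloro in place of trifluoromethyl on this aromatic carbon, meta to a trifluoromethyl group, gives a 3.1-fold lower number from compound 2 to compound 3 (0.48 log units; beyond the scatter), the first single-place step read in the series. Growth inhibition at this position is therefore sensitive to the group it carries, and the trifluoromethyl of compound 2 is not needed there: chloro, with 1 heavy atom in place of 4, gives the lower number. No measurement bearing on the origin of this step is available.

The compounds shown leave open whether the step belongs to chloro itself or to the loss of trifluoromethyl, which hydrogen, fluoro, methyl or methoxy on the same carbon would help separate. Also open, as far as these compounds go, is whether the same exchange at the remaining trifluoromethyl group would shift the number further.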